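Cytotoxicity in the aryl ether series: compound 2 to compound 4

A few compounds are considered here, and "the series" means these few. Any claim that something is new, unique, unknown or untested is made for them only; others in the source may bear on it.

Four compounds share one core. Compound 1 `O=c1ccn(CCCCOc2ccc(Br)cc2)c(=O)[nH]1` and compound 3 `O=c1ccn(CCCOc2ccc(Br)cc2)c(=O)[nH]1` were tested in an ADME assay on HEL cells (Homo sapiens) for cytotoxicity (a lower number here means that less compound is tolerated, a higher number that more compound is tolerated), without a reported result: compound 1 gives "not determined" (no result reported) and compound 3 gives "not determined" (no result reported). Going by the values given here, compound 2 `CCCOC(=O)c1ccc(OCCCCCn2ccc(=O)[nH]c2=O)cc1` is the only member with an entry that carries a number, and that entry is a limit of the assay rather than a measured value: compound 2 gives > 100000 nM. Compound 2 thus stands at the upper edge of what this assay reports, as shown by the limit of > 100000 nM in this assay, at which 1 of the 3 values shown sits. Among the compounds with values here, since no second compound has a number, no step between measured compounds exists in this assay.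

Compound 4 `O=c1ccn(CCCCCOc2ccc(Br)cc2)c(=O)[nH]1` is not yet measured. It differs from compound 2 in one place: bromo in place of propoxycarbonyl on an aromatic carbon. The change is bromo in place of propoxycarbonyl on an aromatic carbon para to a large group. With only a limit for compound 2 to build on, no step beyond the scatter is expected; the step from compound 2 to compound 4 is estimated at a number no higher from compound 2 to compound 4 (the limit leaves the size open). For compound 4 the value in this assay is estimated at 100000 nM. Compound 4 is expected to fall between 30000 nM and 300000 nM, most likely reported again as a limit.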

Compound 4, half-maximal cytotoxic concentration: > 100000 nM
Compound 4 was reported as a limit; the forecaster's own chance of this, stated with the estimate: 75%; the middle value sits exactly at the limit.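

Compound 2 and compound 4 each carry only a limit of the assay in this assay, so no step between them can be read: the limit of > 100000 nM in this assay, at which 2 of the 4 values shown sit.

The compounds shown leave open whether bromo in place of propoxycarbonyl changes the tolerated concentration, and whether any member of the series gives a measurable cytotoxic concentration in this assay.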